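The compounds below may be only part of what the source reports. "The series", "measured", "known", "first", "only" and "open" are said of these compounds alone.

Of the compounds shown here, three from this series have been tested in an assay on HL-60 cells for agonist activity at N-formyl peptide receptor 3 (Homo sapiens), read by calcium flux (on this read-out higher numbers stand for an effect only at larger amounts of compound and lower numbers for an effect already at smaller amounts), and none of them has given a number. Compound 1 `COc1ccc(Cc2cc(-c3ccc(C)cc3)nn(CC(=O)Nc3ccc(Br)cc3)c2=O)cc1` returns only the limit of > 50000 nM in this assay. Compound 2 `Cc1cc(Cc2ccccc2)c(=O)n(CC(=O)Nc2ccc(F)cc2)n1` likewise stops at the limit of > 50000 nM in this assay. Compound 3 `Cc1cc(Cc2cccc(Br)c2)c(=O)n(CC(=O)Nc2ccc(Br)cc2)n1`, the starting point here, also reaches only the limit of > 50000 nM in this assay. Where compound 3 stands is therefore not a place on a scale but the edge of the assay, shared with the other two: the limit of > 50000 nM in this assay, at which 3 of the 3 values shown sit.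

Compound 4 `Cc1cc(Cc2cccnc2)c(=O)n(CC(=O)Nc2ccc(Br)cc2)n1` has not been measured. It differs from compound 3 in one spot: pyridin-3-yl in place of 3-bromophenyl on a saturated chain carbon bound to an aromatic carbon. A 3-bromobenzyl group becomes a (pyridin-3-yl)methyl group.

Among the measured compounds shown here, with every measured compound sitting at the limit, no step between measured pairs exists to lean on. Nothing among the three measured compounds points to activity, so the expectation for compound 4 is that the step from compound 3 to compound 4 in this assay, a step that the limit leaves unreadable from compound 3 to compound 4, is none beyond the scatter. Compound 4 is thus expected to come in at about 60000 nM in this assay, within a range from 20000 nM to 200000 nM, and most probably as a limit once more.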

Compound 4, half-maximal effective concentration: > 50000 nM
Compound 4: only a limit was reported; the forecaster's own chance of this, stated with the estimate: 85%; the middle value is on the limit's open side.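

No step can be read from compound 3 to compound 4, since both stop at the same edge of this assay: the limit of > 50000 nM in this assay, at which 4 of the 4 values shown sit.

The compounds shown leave open whether pyridin-3-yl in place of 3-bromophenyl changes anything at all, and whether any compound of this series gives a readable number in this assay.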